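The compounds below may be only part of what the source reports. "The series", "measured", "known", "first", "only" and "open" are said of these compounds alone.

The series is read in an assay on A549 cells for inhibition of transcription factor p65 (Homo sapiens), read by fluorescence, with a stated time of 2 h; a higher number here means a weaker inhibitor, a lower number a stronger inhibitor. Compound 1 `COc1ccc(/C=C/C(=O)c2ccc(NC(C)=O)c(-c3ccc(F)cc3)c2)cc1OC` gives 2650 nM in this assay. Compound 3 `COc1cc(/C=C/C(=O)c2ccc(N)c(-c3ccc(F)cc3)c2)cc(OC)c1OC` gives 11600 nM in this assay. Compound 2 `O=C(/C=C/c1ccc(Br)cc1)c1cccc(-c2cccc(F)c2)c1` reaches only the limit of this assay, reported as > 50000 nM. That limit is described by the limit of > 50000 nM in this assay, at which 1 of the 3 values shown sits. Compound 2 therefore stands at the weak end of what has been measured here, without a numerical place among the three values.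

Compound 4 `O=C(/C=C/c1ccc(Cl)cc1)c1cccc(-c2cccc(F)c2)c1` has not yet been measured in this assay. It differs from compound 2 by chloro in place of bromo on an aromatic carbon; cut one bond further out, the change reads 4-bromophenyl to 4-chlorophenyl, on an aromatic carbon of a six-membered aromatic ring of carbon only, para to a large group. For the measured compounds named here, no measured pair in this set differs in one place, so no step size is known from the data. The exchange of one halogen for another is expected to move the value by no more than the scatter, and the step is estimated at a step that the limit leaves unreadable from compound 2 to compound 4. Compound 4 is therefore expected to sit near 60000 nM, within 20000 nM to 200000 nM, and is more likely to come back as a limit than as a number.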

Compound 4, half-maximal inhibitory concentration: 24400 nM
Estimate against measurement, compound 4: 2.5-fold (0.39 log units) above, within the range that was stated.
By their numbers in this assay, from the lowest: compound 1; then compound 3; then compound 4. At a limit, above all of these: compound 2.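

In this assay, for the compounds shown here, the change from 4-bromophenyl to 4-chlorophenyl gives an at least 2.0-fold lower number from compound 2 to compound 4 (0.31 log units; beyond the scatter), the only step in this set that can be read, and it shows that the number responds to which halogen sits on this aromatic carbon, para to a large group. Compound 4, carrying chloro, gives 24400 nM, which places this core on the numerical part of the scale. Compound 2 remains a limit and not a number, and the step can therefore be read only as a bound, with its full size unknown: the limit of > 50000 nM in this assay, at which 1 of the 4 values shown sits.

On these data alone, compound 1 and compound 3 differ from compound 4 in more than one place and give no reading of this change on their own cores, and whether the halogen step carries over to those cores stays open. The compounds shown also leave open how this position responds to a group other than a halogen, such as a nitrile or a carboxylic acid in place of the chloro, and whether the position needs a substituent at all.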